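This account rests on a few compounds, and the source may have more. Where it says the series, first, only, none or still open, it means among the compounds named here.

Working notes on the series. Three compounds share a core and have numbers in a functional assay on PC-3 cells (Homo sapiens) for antiproliferative activity, read by MTT assay, with a stated time of 48 h; on this read-out lower numbers stand for stronger inhibition and higher numbers for weaker inhibition. Compound 1 `COc1ccc(N/C=C\C(=O)c2cn(-c3ccccc3)nc2-c2ccc(F)cc2)cc1` gives 4600 nM. Going by the values given here, compound 2 `COc1ccc(N/C=C\C(=O)c2cn(-c3ccccc3)nc2-c2ccc(Cl)cc2)cc1` gives 10700 nM; the one measured step, a 2.3-fold higher number from compound 1 to compound 2 (0.37 log units; beyond the scatter), is the only comparison available. Compound 3 `COc1cc(-c2nn(-c3ccccc3)cc2C(=O)/C=C\Nc2ccc(Cl)cc2)cc(OC)c1OC` gives 11200 nM. Compound 3 and compound 2 lie within the scatter of each other, while compound 3 gives a higher number than compound 1, a gap beyond the scatter.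

Compound 4 `COc1ccc(N/C=C\C(=O)c2cn(-c3ccccc3)nc2-c2cc(OC)c(OC)c(OC)c2)cc1` is not yet measured. Its difference from compound 3 is methoxy in place of chloro on an aromatic carbon. Among the compounds with values here, no measured step covers this change: the step from compound 1 to compound 2 concerns chloro in place of fluoro on the other aryl ring, with the aniline already bearing methoxy, so it gives no direct guide to the present swap. Compounds 1 and 2, which carry the methoxyphenylamino, fall on either side of compound 3 in this assay. The expected step is therefore none beyond the scatter, a 1.4-fold lower number from compound 3 to compound 4 (0.15 log units; within the scatter), with a wide range. The expected value for compound 4 is 8000 nM, between 2500 nM and 25000 nM.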

Compound 4, half-maximal inhibitory concentration: 9600 nM
Compound 4: middle estimate off by 1.2-fold (0.08 log units), on the low side, and the stated range covers the measured number.
By their numbers in this assay, from the lowest: compound 1; then compounds 4, 2 and 3 (each within the scatter of the next).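

With the 3,4,5-trimethoxyphenyl held in place, (4-methoxyphenyl)amino in place of (4-chlorophenyl)amino gives a 1.2-fold lower number from compound 3 to compound 4 (0.07 log units; within the scatter) in this assay, so this change shows no effect that can be separated from the scatter. With the (4-methoxyphenyl)amino held in place, 3,4,5-trimethoxyphenyl in place of 4-chlorophenyl gives a 1.1-fold lower number from compound 2 to compound 4 (0.05 log units; within the scatter), whereas in place of 4-fluorophenyl it gives a 2.1-fold higher number from compound 1 to compound 4 (0.32 log units; beyond the scatter), so on that ring only the 4-fluorophenyl of compound 1 stands apart from the others. No available evidence bears on these steps.

The compounds shown leave open whether the flat result of the chloro to methoxy swap also holds when 4-fluorophenyl sits on the other ring. They also leave open how an amine or a carboxylic acid at the same place on the aniline ring would read.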